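A few compounds are considered here, and "the series" means these few. Any claim that something is new, unique, unknown or untested is made for them only; others in the source may bear on it.

Compound 1 `Nc1cc(OCCNc2ccnc3cc(Cl)ccc23)nc(N)n1`: 174000 nM
Compound 2 `CC(COc1cc(N)nc(N)n1)Nc1ccnc2cc(Cl)ccc12`: 250000 nM
Compound 3 `Nc1cc(OCCCNc2ccnc3cc(Cl)ccc23)nc(N)n1`: 107000 nM

All three compounds were tested in an ADME assay on CHO cells (Cricetulus griseus) for cytotoxicity, read by MTT assay, with a stated time of 48 h (on this read-out lower numbers stand for stronger inhibition and higher numbers for weaker inhibition), and all three numbers are large. Compound 2, at 250000 nM, cannot be told apart from compound 1, since the gap between them lies within the scatter. The number for compound 3, 107000 nM, is lower than that of compound 2, and this gap lies beyond the scatter.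

The next compound to be tested is compound 4 `CCC(COc1cc(N)nc(N)n1)Nc1ccnc2cc(Cl)ccc12`. It differs from compound 2 by a single change: methyl in place of hydrogen on a saturated chain carbon, two bonds along the chain from a nitrogen on an aromatic ring. Put another way, the methyl on the chain of compound 2 becomes an ethyl.

Going by the values given here, only one measured step bears on this change. It is the addition of a methyl to the same chain, which gave a 1.4-fold higher number from compound 1 to compound 2 (0.16 log units; within the scatter). That single small step is thin evidence, but it gives no reason to expect a large shift when the chain grows by one more carbon. No change beyond the scatter is therefore expected in this assay, and no direction can be firmly predicted.

The expected result is a 1.1-fold lower number from compound 2 to compound 4 (0.06 log units; within the scatter). For compound 4 the estimated value is 220000 nM, with an expected range from 110000 nM to 420000 nM.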

Compound 4, half-maximal inhibitory concentration in the CHO assay: 156000 nM
Beside the measured number, compound 4's estimate is 1.4-fold (0.15 log units) above it, within the range that was stated.
By their numbers in the CHO assay, from the lowest: compounds 3, 4, 1 and 2 (each within the scatter of the next, the first and the last beyond it).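

In the CHO assay, growing the methyl on this chain carbon into an ethyl moves the number very little, with a 1.6-fold lower number from compound 2 to compound 4 (0.20 log units; within the scatter). Measured against the unbranched chain, the ethyl group makes just as small a difference, with a 1.1-fold lower number from compound 1 to compound 4 (0.05 log units; within the scatter), so compounds 1, 2 and 4 cannot be told apart in this assay, and this position tolerates hydrogen, methyl or ethyl without a readable change. The same single carbon has a large effect on a different property, however, so a change that looks harmless in the cell read-out can still matter a great deal for how much compound stays in solution, as a physicochemical assay for solubility, read by HPLC, in phosphate buffer, with a stated time of 24 h, at 37 degrees C, at pH 5.5 (on this read-out lower numbers stand for lower solubility and higher numbers for higher solubility), shows: the measured solubility of compound 2, 1450 nM, and of compound 4, 40 nM, a 36-fold lower number (1.56 log units; beyond the scatter)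

In the physicochemical assay compound 2 gives 1450 nM and compound 4 gives 40 nM. This solubility drop rests on one pair of compounds, so it cannot yet be called a trend along the chain. Going by these compounds, it remains open whether a longer chain such as propyl would lower the number in the physicochemical assay further, and whether an amine or a hydroxyl group on this carbon would keep the number in the CHO assay unchanged while giving a different result for solubility.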